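The source may report more compounds than this note shows. Statements on the series, on what has been measured and on what is new or still open speak of the compounds shown alone.

Measured compounds in a functional assay on the whole organism with Rattus norvegicus as the target, at a dose of 20 mg/kg by the oral route; a lower number here means less inhibition, a higher number more inhibition at the dose given (going by the name of the read-out):
compound 1 `O=C(/C=C1\CCc2ccc(F)cc21)NCCO` gives 78%;
compound 2 `CNC(=O)/C=C1\CCc2ccc(F)cc21` gives 38%.

Compound 2 stands lowest of the two numbers, and the step of a number 40 percentage points lower from compound 1 to compound 2 (beyond the scatter) separates it from compound 1. Compound 3 `CCN(C)C(=O)/C=C1\CCc2ccc(F)cc21` carries ethyl in place of hydrogen on an amide-type nitrogen. Among the compounds with values here, the only measured step concerns a different change, hydrogen in place of hydroxymethyl on a saturated chain carbon bound to an amide-type nitrogen, and it gives no guidance on ethyl entering at the amide-type nitrogen, so no direction can be read from it. For compound 3 the expected step is a number 2 percentage points higher from compound 2 to compound 3 (within the scatter). The estimate for compound 3 is 40%, between 15% and 65%.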

Compound 3, a percentage reported as inhibition, in the whole organism at one dose (the size of the read-out at that dose, not a potency): 44%
Compound 3: middle estimate off by 4 percentage points, on the low side, within the range that was stated.
By their numbers in this assay, from the lowest: compounds 2 and 3 (each within the scatter of the next); then compound 1.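

In this assay, ethyl on the amide-type nitrogen gives (a number 6 percentage points higher from compound 2 to compound 3 (within the scatter)), so adding this group to the methyl amide leaves the number within the scatter. Ethyl(methyl)amino in place of (2-hydroxyethyl)amino on the carbonyl carbon gives (a number 34 percentage points lower from compound 1 to compound 3 (beyond the scatter)), so this second amide without the hydroxyl group also stands well beneath compound 1. The compounds shown leave open whether an amine or a carboxylic acid at the end of the chain, or a longer chain ending in hydroxyl, would match compound 1. No measurement shown here explains these steps.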